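Aryl urea series: halogen-position change at the anilide nitrogen

This account rests on a few compounds, and the source may have more. Where it says the series, first, only, none or still open, it means among the compounds named here.

Compound 2 `O=C(Nc1ccccc1Br)N[C@H]1CC[C@H](Oc2ccc(F)cc2)CC1` gives the highest of the two numbers measured in a functional assay on CRL2813 cells (Homo sapiens) for cytotoxicity, read by sulforhodamine B assay, with a stated time of 5 days (on this read-out higher numbers stand for weaker inhibition and lower numbers for stronger inhibition), at 7700 nM; compound 1 `O=C(Nc1ccc([N+](=O)[O-])cc1)N[C@H]1CC[C@H](Oc2ccc(F)cc2)CC1` gives 2300 nM. Within the data shown here, the single measured step, a 3.3-fold higher number from compound 1 to compound 2 (0.52 log units; beyond the scatter), concerns a different aryl exchange at the same nitrogen. Compound 3 `O=C(Nc1cccc(Cl)c1)N[C@H]1CC[C@H](Oc2ccc(F)cc2)CC1` differs from compound 2 by 3-chlorophenyl in place of 2-bromophenyl on an amide-type nitrogen. Among the measured compounds shown here, no measured step bears directly on this change, so the expectation rests only on the spread seen so far. Compound 3 is expected to move no more than modestly, in either direction: a 1.5-fold lower number from compound 2 to compound 3 (0.19 log units; within the scatter). Compound 3 is therefore estimated at 5000 nM, with a range of 1800 nM to 14000 nM.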

Compound 3, half-maximal inhibitory concentration: 5900 nM
Beside the measured number, compound 3's estimate is 1.2-fold (0.07 log units) below it; low and high end bracket the measured number.
By their numbers in this assay, from the lowest: compound 1; then compounds 3 and 2 (each within the scatter of the next).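

In this assay, a 1.3-fold lower number from compound 2 to compound 3 (0.12 log units; within the scatter) shows that 3-chlorophenyl and 2-bromophenyl are not separated at this amide-type nitrogen. The second new step, a 2.6-fold higher number from compound 1 to compound 3 (0.41 log units; beyond the scatter), puts the 3-chlorophenyl compound on the same side of 4-nitrophenyl as the earlier bromo step, so both halogenated aryl groups read higher than 4-nitrophenyl. No supporting data bear on the reason for this result.

The step changes the halogen and its ring position together, and neither can be read alone. Going by these compounds, how a phenyl group carrying an amine or a carboxylic acid would read at this nitrogen also stays open.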